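From Benzoyl to a Bulky Urea: Expecting Low Toxicity

The source may report more compounds than this note shows. Statements on the series, on what has been measured and on what is new or still open speak of the compounds shown alone.

Measured so far:
- Compound 1, `O=C(c1ccccc1)N(CCCCCCN1C[C@H](O)[C@@H](O)[C@H](O)[C@H]1CO)C1CCCCC1`. In an ADME assay on MDBK cells (Bos taurus) for cytotoxicity, read by MTT assay (on this read-out lower numbers stand for higher toxicity in this test and higher numbers for lower toxicity in this test), compound 1 gives > 500000 nM, which is a limit of the assay rather than a number.
- Compound 2, `CCCNC(=O)N(CCCCCCN1C[C@H](O)[C@@H](O)[C@H](O)[C@H]1CO)C1CCCCC1`. In this assay compound 2 gives > 500000 nM, again only a limit.

Going by the values given here, compound 1 therefore stands at the edge of what this assay can report: only a limit is known for it, and the one further value shown is a limit as well (the limit of > 500000 nM in this assay, at which 2 of the 2 values shown sit). Compound 3, `CC(C)(C)NC(=O)N(CCCCCCN1C[C@H](O)[C@@H](O)[C@H](O)[C@H]1CO)C1CCCCC1`, differs from compound 1 by (tert-butyl)amino in place of phenyl on a carbonyl carbon. Among the compounds with values here, the one measured step that bears on this change is a step that the two limits leave unreadable from compound 1 to compound 2, in which propylamino likewise takes the place of phenyl on a carbonyl carbon; its size cannot be read. Nothing here points to a step beyond the scatter in this assay, so compound 3 is expected to give only a limit again, with the expected step of a number no higher from compound 1 to compound 3 (the limit leaves the size open). The estimate for compound 3 in this assay is 500000 nM, between 150000 nM and 2000000 nM.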

Compound 3, half-maximal cytotoxic concentration: > 500000 nM
Compound 3: no number, only a limit; the forecaster's own chance of this, stated with the estimate: 85%; the middle value sits exactly at the limit.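

In this assay compound 3 gives > 500000 nM, which is a limit and not a number. The steps linking compound 1, compound 2 and compound 3 therefore cannot be read, and all three compounds share one ceiling: the limit of > 500000 nM in this assay, at which 3 of the 3 values shown sit. The compounds shown leave open how far apart their true values lie and whether any change to the group on the carbonyl carbon affects toxicity in this test.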